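The compounds below may be only part of what the source reports. "The series", "measured", "known", "first", "only" and "open" are said of these compounds alone.

Compound 1 `COc1cc2c(Oc3ccc(NC(=O)c4cc(-c5ccccc5)ccn4)cc3F)ccnc2cc1OCCCN1CCCCC1` was tested in a functional assay on HT-29 cells (Homo sapiens) for cytotoxicity, read by MTT assay, with a stated time of 72 h (a lower number here means a stronger inhibitor, a higher number a weaker inhibitor), where compound 1 gives 270 nM. Compound 2 `COc1cc2c(Oc3ccc(NC(=O)c4cc(-c5ccc(C)cc5)ccn4)cc3F)ccnc2cc1OCCCN1CCCCC1` carries one change relative to compound 1, (methyl in place of hydrogen on an aromatic carbon), and in this assay compound 2 gives 340 nM. That single change produced a 1.3-fold higher number from compound 1 to compound 2 (0.10 log units; within the scatter). Compound 3 `COc1cc2c(Oc3ccc(NC(=O)c4nccc(-c5ccccc5)n4)cc3F)ccnc2cc1OCCCN1CCCC1` has a different core; how the core of compound 3 differs from the core of compound 1 is not broken down here. In this assay compound 3 gives 390 nM, and its value, that of compound 2 and that of compound 1 all lie within the scatter of one another.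

Compound 4 `COc1cc2c(Oc3ccc(NC(=O)c4nccc(-c5ccc(C)cc5)n4)cc3F)ccnc2cc1OCCCN1CCCC1` is not yet measured. It differs from compound 3 by methyl in place of hydrogen on an aromatic carbon. The place of this change is described in the same words as for the pair of compound 1 and compound 2, so it is the same change made on a different core. The step from compound 3 to compound 4 is expected to be a 1.3-fold higher number from compound 3 to compound 4 (0.11 log units; within the scatter), resting on the earlier 1.3-fold higher number from compound 1 to compound 2 (0.10 log units; within the scatter) seen between compound 1 and compound 2. Compound 4 is therefore estimated at 500 nM, with a range from 250 nM to 1000 nM.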

Compound 4, half-maximal inhibitory concentration: 670 nM
Compound 4: middle estimate off by 1.3-fold (0.13 log units), on the low side; low and high end bracket the measured number.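

In this assay, the change from phenyl to 4-methylphenyl gave a 1.7-fold higher number from compound 3 to compound 4 (0.24 log units; within the scatter) on the core of compound 3, and this step, like the earlier one on the core of compound 1, stays within the usual scatter. Set side by side, the two steps cannot be told apart: the same change on two cores in this assay, a 1.3-fold higher number (0.10 log units; within the scatter) from compound 1 to compound 2 and a 1.7-fold higher number (0.24 log units; within the scatter) from compound 3 to compound 4, 1.4-fold (0.13 log units) apart, within the scatter of two such steps. The change therefore carried from one core to the other without a step on either core that stands clear of the scatter, but this does not show that the methyl group has a real effect on either core, and two pairs cannot show how it would behave on any further core.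

The compounds shown leave open how a larger or differently built group in the same place would read, such as an ethyl group, a methoxy group, a chlorine atom, an amine or a carboxylic acid. They also leave open whether any such group would give a step beyond the scatter on both cores.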